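Swapping the Pyridine Substituent: Dimethylamino to Methoxymethyl

The source may hold more compounds than are shown below. What is called first, only, known or untested is meant among the compounds shown, and "the series" means these compounds.

Measured compounds:
compound 1 `Cc1cc(-c2noc([C@H](C)NC(=O)c3cc(C(F)(F)F)nn3C)n2)ncn1` gives 1410 nM
compound 2 `C[C@H](NC(=O)c1cc(C(F)(F)F)nn1C)c1nc(-c2ccnc(N(C)C)c2)no1` gives 454 nM

Among the compounds with values here, in an assay on T-REx-293 cells for inhibition of potassium channel subfamily T member 1 (Homo sapiens), read by patch clamp (on this read-out lower numbers stand for stronger inhibition and higher numbers for weaker inhibition), compound 2 stands at the lowest number of the two measured, and its only neighbour is compound 1, which sits at a higher number. Within the data shown here, the one step seen so far is a 3.1-fold lower number from compound 1 to compound 2 (0.49 log units; beyond the scatter); it came from exchanging the whole aromatic group on the shared core and was modest in size.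

Compound 3 `COCc1cc(-c2noc([C@H](C)NC(=O)c3cc(C(F)(F)F)nn3C)n2)ccn1` is the next candidate. It differs from compound 2 by methoxymethyl in place of dimethylamino on an aromatic carbon. The leaving and entering groups are matched in their count of heavy atoms and acceptors, so this is a smaller alteration than the ring exchange behind compound 1 and compound 2. The expectation is therefore a small shift, a 1.7-fold higher number from compound 2 to compound 3 (0.22 log units; within the scatter), toward a somewhat higher number. Compound 3 is estimated at 750 nM, within a range from 250 nM to 2200 nM.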

Compound 3, half-maximal inhibitory concentration: 322 nM
Compound 3: middle estimate off by 2.3-fold (0.37 log units), on the high side; low and high end bracket the measured number.
By their numbers in this assay, from the lowest: compounds 3 and 2 (each within the scatter of the next); then compound 1.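

In this assay, methoxymethyl in place of dimethylamino, next to the ring nitrogen, gives a 1.4-fold lower number from compound 2 to compound 3 (0.15 log units; within the scatter) and so leaves the reading unchanged within the usual scatter. Set against the 6-methylpyrimidin-4-yl group, 2-(methoxymethyl)pyridin-4-yl gives a 4.4-fold lower number from compound 1 to compound 3 (0.64 log units; beyond the scatter) and lies beyond the scatter, so among these compounds the lower number does not depend on dimethylamino being present at this position. Nothing measured here accounts for why these two groups read alike.

The compounds shown leave open how a longer chain such as ethoxymethyl, a hydroxymethyl group or a carboxylic acid would read at this position. They also leave open whether a plain pyridin-4-yl group, carrying only hydrogen there, would hold the number, which would show whether any group is needed at this position at all.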